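The source may report more compounds than this note shows. Statements on the series, on what has been measured and on what is new or still open speak of the compounds shown alone.

Among the compounds with values here, in a functional assay on HepG2 cells (Homo sapiens) for antiproliferative activity, read by CCK-8 assay, with a stated time of 48 h (a lower number here means a stronger inhibitor, a higher number a weaker inhibitor), compound 2 (`COc1ccc(/C=C\c2cc(OC)c(OC)c(OC)c2)cc1OCc1ccc(CNCCO)cc1`) gives 5900 nM, the only actual number so far. Compound 1 (`COc1ccc(/C=C\c2cc(OC)c(OC)c(OC)c2)cc1OCc1ccc(CN2CCCC[C@@H]2C(=O)O)cc1`) is reported as a limit of the assay, > 10000 nM. Compound 3 (`COc1ccc(/C=C\c2cc(OC)c(OC)c(OC)c2)cc1OCc1ccc(CN2CC[C@H](C(=O)O)C2)cc1`) keeps the shared core and changes one group on a saturated chain carbon bound to an aromatic carbon: 3-carboxypyrrolidin-1-yl in place of (2-hydroxyethyl)amino on a saturated chain carbon bound to an aromatic carbon. In this change, 3-carboxypyrrolidin-1-yl replaces (2-hydroxyethyl)amino. Within the data shown here, the one measured step that bears on this is an at least 1.6-fold lower number from compound 1 to compound 2 (0.22 log units; that floor lies within the scatter), where (2-hydroxyethyl)amino replaces 2-carboxypiperidin-1-yl. That step is known only as a floor, and the floor lies within the scatter, so it gives weak guidance. Its direction is still the only hint available, and compound 3 brings back a carboxy-bearing ring. A move towards a higher number in this assay is therefore expected, though only a modest one. The expected change is a 1.9-fold higher number from compound 2 to compound 3 (0.27 log units; within the scatter), a step of about the size of the scatter. For compound 3 the estimated value is 11000 nM, with an expected range from 5000 nM to 30000 nM, and a result reported only as a limit would not be surprising.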

Compound 3, half-maximal inhibitory concentration: 6400 nM
Beside the measured number, compound 3's estimate is 1.7-fold (0.24 log units) above it, and the stated range covers the measured number.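

In this assay, the step is a 1.1-fold higher number from compound 2 to compound 3 (0.04 log units; within the scatter), so at this saturated chain carbon bound to an aromatic carbon, 3-carboxypyrrolidin-1-yl and (2-hydroxyethyl)amino cannot be told apart. Compound 3 thus shows that a ring bearing a carboxylic acid at this place can still give a measured number, so the earlier hint from 2-carboxypiperidin-1-yl does not hold for every such ring, while the direct comparison, an at least 1.5-fold lower number from compound 1 to compound 3 (0.19 log units; that floor lies within the scatter), cannot separate the two rings. Compound 1 remains a limit of the assay and not a number: the limit of > 10000 nM in this assay, at which 1 of the 3 values shown sits.

The two rings differ in size and in where the carboxylic acid sits, so the compounds shown cannot say which of these features, if either, matters, nor what the defined stereocentre of 3-carboxypyrrolidin-1-yl contributes. Going by these compounds, it also remains open how an unsubstituted pyrrolidine, the methyl ester of the carboxylic acid, or a longer hydroxyalkyl chain would read at this place.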